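Aminocarbamoyl in Place of Carbamoyl: Cytotoxicity Expectation

This account rests on a few compounds, and the source may have more. Where it says the series, first, only, none or still open, it means among the compounds named here.

Measured compounds in an ADME assay on TZM cells (Homo sapiens) for cytotoxicity, read by XTT assay, with a stated time of 4 days; on this read-out higher numbers stand for lower toxicity in this test and lower numbers for higher toxicity in this test:
- Compound 1, `Cc1cc(CCC#N)cc(C)c1Oc1cc(Nc2ccc(C#N)cc2)c(N)cc1S(N)(=O)=O`, gives 11100 nM.
- Compound 2, `Cc1cc(CCC#N)cc(C)c1Oc1cc(Nc2ccc(C#N)cc2)c(N)cc1C(F)(F)F`, is reported only as a limit, > 7100 nM.
- Compound 3, `Cc1cc(CCC#N)cc(C)c1Oc1cc(Nc2ccc(C#N)cc2)c(N)cc1C(N)=O`, is reported only as a limit, > 9400 nM.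

All three compounds share one core and differ only in the group on one aromatic carbon. Compound 3 stands at a limit rather than a number. Its place among the three therefore cannot be fixed: the step that the limit leaves unreadable from compound 1 to compound 3 cannot be read, and the same holds for a step that the limit leaves unreadable from compound 1 to compound 2 and a step that the two limits leave unreadable from compound 2 to compound 3. What can be said is little. Compound 1 sits at 11100 nM. For compound 2 only a limit is given, (the limit of > 7100 nM in this assay, at which 1 of the 3 values shown sits). For compound 3 only a limit is given, (the limit of > 9400 nM in this assay, at which 1 of the 3 values shown sits).

Compound 4, `Cc1cc(CCC#N)cc(C)c1Oc1cc(Nc2ccc(C#N)cc2)c(N)cc1C(=O)NN`, is the next compound. Its difference from compound 3 is amino in place of hydrogen on an amide-type nitrogen. No measured step bears on this change: the three steps shown all concern the group on the aromatic carbon, and all three are unreadable. With nothing to push the expectation either way, compound 4 is expected to sit near compound 3 in this assay, with a step that the limit leaves unreadable from compound 3 to compound 4 that is expected to stay within the scatter. The estimate for compound 4 is therefore 10000 nM, with a range from 4000 nM to 30000 nM, and a good chance that only a limit is again reported.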

Compound 4, half-maximal cytotoxic concentration: > 22700 nM
Compound 4: only a limit was reported (the forecaster's own chance of this, stated with the estimate: 60%); middle value at least 2.2-fold (0.35 log units) away from the limit.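

In this assay compound 4 is again reported only as a limit, > 22700 nM. It nevertheless gives this aromatic carbon its first readable step, an at least 2.0-fold higher number from compound 1 to compound 4 (0.31 log units; beyond the scatter), with aminocarbamoyl in place of sulfamoyl, so compound 4 shows lower toxicity in this test than compound 1 by more than the usual scatter. All the other steps among the four compounds cannot be read, including the one for amino in place of the amide hydrogen, so the data show no size or direction for that change on its own.

The true positions of compound 2, compound 3 and compound 4 remain open, and with them any order among these three, since each carries only a limit. Also open, from the compounds shown here alone, is how other groups would read in this assay, for example a methyl or a hydroxyl on the amide-type nitrogen, or a carboxylic acid or a simple amine on the aromatic carbon.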